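The source may report more compounds than this note shows. Statements on the series, on what has been measured and on what is new or still open speak of the compounds shown alone.

Compound 1, `CC(=O)Oc1ccc2c(c1)C(C)=CC(C)(C)N2Cc1cccc(Cl)c1`, was examined in an ADME assay on L6 cells (Rattus norvegicus) for cytotoxicity, read by resazurin assay, with a stated time of 70 h (a higher number here means a weaker inhibitor, a lower number a stronger inhibitor), where compound 1 gives 29000 nM. Compound 2, `CC(=O)Oc1ccc2c(c1)C(C)=CC(C)(C)N2Cc1cccc(C)c1`, differs from compound 1 by one change, (methyl in place of chloro on an aromatic carbon), and in this assay compound 2 gives 28000 nM. The step of a 1.0-fold lower number from compound 1 to compound 2 (0.02 log units; within the scatter) shows that swapping these two groups at this position leaves the read-out essentially unchanged.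

Compound 3, `COc1cc(OC)cc(C(=O)Oc2ccc3c(c2)C(C)=CC(C)(C)N3Cc2ccc(Cl)cc2)c1`, carries a different core, and the difference between the core of compound 3 and the core of compound 1 is not broken down here. For compound 3 only a limit is known in this assay: compound 3 gives > 190000 nM, which is a limit of the assay and not a number. This is the situation described by the limit of > 190000 nM in this assay, at which 1 of the 3 values shown sits.

Compound 4, `COc1cc(OC)cc(C(=O)Oc2ccc3c(c2)C(C)=CC(C)(C)N3Cc2ccc(C)cc2)c1`, has not been measured. It differs from compound 3 by methyl in place of chloro on an aromatic carbon. Among the compounds with values here, this is the same kind of change as the one from compound 1 to compound 2, though the place is not identical: in the earlier pair the group sits meta to a large group, here it sits para to a large group. Since the earlier step was within the scatter, the step from compound 3 to compound 4 is expected to be small as well, roughly a step that the limit leaves unreadable from compound 3 to compound 4. On that basis compound 4 is estimated to come out at 250000 nM, most likely again reported only as a limit, with a plausible range from 120000 nM to 600000 nM.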

Compound 4, half-maximal inhibitory concentration: > 200000 nM
Compound 4: no number, only a limit (the forecaster's own chance of this, stated with the estimate: 80%); the middle value is on the limit's open side.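

In this assay compound 3 gives > 190000 nM and this is a limit of the assay, not a number. Compound 4 gives > 200000 nM and this too is a limit, not a number. The step from compound 3 to compound 4 therefore cannot be read. The compounds shown leave open whether methyl in place of chloro at this place changes the read-out when the ester is the larger one carried by compound 3 and compound 4.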